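From bromo to methyl on a shared core

This account rests on a few compounds, and the source may have more. Where it says the series, first, only, none or still open, it means among the compounds named here.

Compound 1 `O=C(/C=C/c1ccc(Br)cc1)Nc1cc(-c2ccc(Br)cc2)[nH]n1`: 1280 nM
Compound 2 `O=C(/C=C/c1ccccc1)Nc1cc(-c2ccc(Br)cc2)[nH]n1`: 1270 nM

In a functional assay on B16-F10 cells (Mus musculus) for antiproliferative activity, read by MTT assay, with a stated time of 48 h (on this read-out lower numbers stand for stronger inhibition and higher numbers for weaker inhibition), compound 1 gives 1280 nM, within the scatter of compound 2 at 1270 nM. Compound 3 `Cc1ccc(-c2cc(NC(=O)/C=C/c3ccc(Br)cc3)n[nH]2)cc1` keeps the core of compound 1 and changes one group: methyl in place of bromo on an aromatic carbon, para to a large group. Among the measured compounds shown here, the only measured step, a 1.0-fold lower number from compound 1 to compound 2 (0.00 log units; within the scatter), replaces the other bromo with hydrogen and lies within the scatter, so it offers only weak guidance here. No direction is favoured, and the expected change, a 1.1-fold higher number from compound 1 to compound 3 (0.04 log units; within the scatter), stays within the scatter. For compound 3 the expected value is 1400 nM, with an estimated range of 500 nM to 3800 nM.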

Compound 3, half-maximal inhibitory concentration: 1570 nM
Compound 3: middle estimate off by 1.1-fold (0.05 log units), on the low side; the measured number falls inside the stated range.
By their numbers in this assay, from the lowest: compounds 2, 1 and 3 (each within the scatter of the next).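

The earlier step changed the other bromo, while this one changes the bromo para to a large group. In this assay, going from 4-bromophenyl to 4-methylphenyl gives a 1.2-fold higher number from compound 1 to compound 3 (0.09 log units; within the scatter), so on this evidence a methyl here leaves the number where a bromo puts it. As far as these compounds go, only these two small groups have been compared at this position, so it remains open whether an amine, a carboxylic acid or a longer chain on the same carbon would also stay within the scatter. No supporting data are available to explain why the two numbers sit so close.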